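Three amides at a limit, a fourth awaited

This account rests on a few compounds, and the source may have more. Where it says the series, first, only, none or still open, it means among the compounds named here.

Compound 3 `O=C(COc1ccc2cc(/C=C3/SC(=O)NC3=O)ccc2c1)Nc1c(F)cc(F)cc1Br` carries a 2-bromo-4,6-difluorophenyl on the amide-type nitrogen of a core it shares with two other compounds. In an assay on isolated protein for inhibition of histone deacetylase 8 (Homo sapiens), with a stated time of 1 h (a higher number here means a weaker inhibitor, a lower number a stronger inhibitor), compound 3 gives > 50000 nM, which is a limit of the assay and not a number. Compound 1 `O=C(COc1ccc2cc(/C=C3/SC(=O)NC3=O)ccc2c1)Nc1ccc(F)cc1F`, with a 2,4-difluorophenyl on that nitrogen, gives in this assay > 50000 nM, again a limit. Compound 2 `COc1ccc(NC(=O)COc2ccc3cc(/C=C4/SC(=O)NC4=O)ccc3c2)cc1`, with a 4-methoxyphenyl there, gives in this assay > 50000 nM, likewise a limit. Compound 3 therefore stands together with the other two at the limit of > 50000 nM in this assay, at which 3 of the 3 values shown sit. The step that the two limits leave unreadable from compound 1 to compound 3, the step that the two limits leave unreadable from compound 1 to compound 2 and the step that the two limits leave unreadable from compound 2 to compound 3 are all unreadable, each running from one limit to another.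

Compound 4 `O=C(COc1ccc2cc(/C=C3/SC(=O)NC3=O)ccc2c1)Nc1ccc(Br)cc1` differs from compound 3 in one place: 4-bromophenyl in place of 2-bromo-4,6-difluorophenyl on an amide-type nitrogen. The three unreadable steps are the only measured ones that bear on this change, and none of them shows a size. With all three measured compounds sitting at the limit of > 50000 nM in this assay, at which 3 of the 3 values shown sit, the expectation is that compound 4 also stays at that limit, so that the step that the limit leaves unreadable from compound 3 to compound 4 is expected to be none beyond the scatter. The estimate for compound 4 in this assay is 60000 nM, with an expected range from 20000 nM to 200000 nM.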

Compound 4, half-maximal inhibitory concentration: 16000 nM
The estimate for compound 4 lay 3.8-fold (0.57 log units) above the measured number, outside the stated range (below it).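

Compound 4 gives 16000 nM in this assay. For the compounds shown here, a change of group on the amide-type nitrogen can therefore lift a compound of this series off the limit, something the earlier compounds could not show, as the steps among them cannot be read. The 4-bromophenyl group gives an at least 3.1-fold lower number from compound 3 to compound 4 (0.49 log units; beyond the scatter), with bromo in place of methoxy on an aromatic carbon the result is an at least 3.1-fold lower number from compound 2 to compound 4 (0.49 log units; beyond the scatter), and against the 2,4-difluorophenyl group it is an at least 3.1-fold lower number from compound 1 to compound 4 (0.49 log units; beyond the scatter). Bromine in the group does not settle the matter alone, since compound 3 also carries it within its 2-bromo-4,6-difluorophenyl, and compound 4 remains the only compound here with a number, the others staying at the limit: the limit of > 50000 nM in this assay, at which 3 of the 4 values shown sit.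

On these data alone, the true size of each step stays open, as each runs from a limit and gives only a bound. Also open, as far as these compounds go, is whether a 4-chlorophenyl, a 4-aminophenyl or a phenyl bearing a carboxylic acid on that nitrogen would give a number in this assay, and how such a number would compare with that of compound 4.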